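Moving the halogen on the hydrazone aryl ring

The compounds below may be only part of what the source reports. "The series", "measured", "known", "first", "only" and "open" are said of these compounds alone.

For the measured compounds named here, compound 2 `CN(C)CCn1cnnc1-c1cc(Oc2ccc(NC(=O)N/N=C/c3cccc(Br)c3)cc2F)ccn1` gives in a functional assay on MKN-45 cells (Homo sapiens) for cytotoxicity, read by MTT assay, with a stated time of 72 h (on this read-out lower numbers stand for stronger inhibition and higher numbers for weaker inhibition), a value of 450 nM, the higher of the two numbers known so far. Compound 1 `CN(C)CCn1cnnc1-c1cc(Oc2ccc(NC(=O)N/N=C/c3cccc(Cl)c3Cl)cc2F)ccn1` gives 51 nM. Going by the values given here, the single measured step, an 8.8-fold higher number from compound 1 to compound 2 (0.95 log units; beyond the scatter), shows that the halogen pattern on this aryl ring can move the number well beyond the scatter. Compound 3 `CN(C)CCn1cnnc1-c1cc(Oc2ccc(NC(=O)N/N=C/c3ccc(Cl)cc3)cc2F)ccn1` differs from compound 2 by 4-chlorophenyl in place of 3-bromophenyl on a carbon with a double bond to nitrogen. Among the compounds with values here, no measured step covers this exact change; the step from compound 1 to compound 2 bears on it only in showing that rearranging halogens on this ring is consequential, without saying in which direction a single chlorine at the 4-position would act. Compound 3 is therefore expected to sit between the two neighbours, with a step of a 1.5-fold lower number from compound 2 to compound 3 (0.18 log units; within the scatter) expected toward a lower number, though possibly within the scatter. Compound 3 is estimated at 300 nM, with a range from 80 nM to 1200 nM.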

Compound 3, half-maximal inhibitory concentration: 570 nM
The estimate for compound 3 lay 1.9-fold (0.28 log units) below the measured number; measured number inside the range.
By their numbers in this assay, from the lowest: compound 1; then compounds 2 and 3 (each within the scatter of the next).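

In this assay, 4-chlorophenyl in place of 3-bromophenyl gives a step within the scatter (a 1.3-fold higher number from compound 2 to compound 3 (0.10 log units; within the scatter)), so this change of halogen and its place on the ring does not separate compound 2 from compound 3 on this read-out. The second new step (an 11-fold higher number from compound 1 to compound 3 (1.05 log units; beyond the scatter)) shows that the separation seen earlier was not peculiar to compound 2: the 2,3-dichlorophenyl of compound 1 gives the lowest number against both rings that carry a single halogen. None of these three compounds goes against that grouping, but three compounds do not establish a general pattern.

The compounds shown leave open how a methoxy group or a nitrile on this ring would compare with the halogens. They also leave open whether a single chlorine and a single bromine would still match if each stood at the same place on the ring. No measurement offered here accounts for the difference between these rings.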